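Methoxy in Place of Methyl: Acid Solubility Outlook

The source may report more compounds than this note shows. Statements on the series, on what has been measured and on what is new or still open speak of the compounds shown alone.

Compound 1 `Cc1cccc2c(NCc3ccco3)nc(NC(C)C)nc12` and compound 3 `COc1cccc2c(NCc3ccco3)nc(NC(C)C)nc12` share one core, while compound 2 `Cc1cccc2nc(NC(C)C)nc(NCc3ccco3)c12` is built from the same atoms as compound 1, joined differently; the difference between the two cores is not broken down here. In a physicochemical assay for solubility, at pH 2 (a lower number here means a less soluble compound, a higher number a more soluble compound), compound 1 gives >= 30000 nM, which is a limit of the assay rather than a number. In this assay compound 2 gives >= 30000 nM, also a limit. In this assay compound 3 gives >= 30000 nM, again a limit. The change from compound 1 to compound 3 is methoxy in place of methyl on an aromatic carbon, and in this assay it amounts to a step that the two limits leave unreadable from compound 1 to compound 3, because of the limit of >= 30000 nM in this assay, at which 3 of the 3 values shown sit. Compound 4 `COc1cccc2nc(NC(C)C)nc(NCc3ccco3)c12` arises from compound 2 by the same change, (methoxy in place of methyl on an aromatic carbon). The step from compound 2 to compound 4 in this assay is expected to be a number no higher from compound 2 to compound 4 (the limit leaves the size open), resting on compound 1 and compound 3 both sitting at the limit of >= 30000 nM in this assay, at which 3 of the 3 values shown sit. Compound 4 is therefore estimated at 30000 nM, between 15000 nM and 60000 nM.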

Compound 4, solubility: >= 30000 nM
Compound 4 was reported as a limit (the forecaster's own chance of this, stated with the estimate: 85%); the middle value lies on the limit itself.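

In this assay no step can be read from compound 2 to compound 4, because both values are limits: the limit of >= 30000 nM in this assay, at which 4 of the 4 values shown sit. The compounds shown leave open how far any of the four compounds lies past that limit.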